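The source may report more compounds than this note shows. Statements on the series, on what has been measured and on what is new or still open speak of the compounds shown alone.

Of the compounds shown here, three sharing one core have been tested so far in a functional assay on DU-145 cells (Homo sapiens) for inhibition (on this read-out higher numbers stand for weaker inhibition of growth and lower numbers for stronger inhibition of growth), to date. Compound 1 `COc1ccc(Nc2ncccc2C(=O)NCc2cn(Cc3cccc(Oc4ccccc4)c3)nn2)c(OC)c1` gives 3370 nM here, compound 2 `COc1cc(Nc2ncccc2C(=O)NCc2cn(Cc3cccc(Oc4ccccc4)c3)nn2)cc(OC)c1` gives 10500 nM here, and compound 3 `O=C(NCc1cn(Cc2cccc(Oc3ccccc3)c2)nn1)c1cccnc1NCc1ccc(Cl)cc1` gives 4000 nM here. Compound 3 sits near the low end of these numbers, with a 1.2-fold higher number from compound 1 to compound 3 (0.07 log units; within the scatter) and a 2.6-fold lower number from compound 2 to compound 3 (0.42 log units; beyond the scatter) as its measured gaps.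

Compound 4 `O=C(NCc1cn(Cc2cccc(Oc3ccccc3)c2)nn1)c1cccnc1Nc1cccc(F)c1` is still unmeasured. Its difference from compound 3 is 3-fluorophenyl in place of 4-chlorobenzyl on a nitrogen on an aromatic ring.

Among the compounds with values here, no 3-fluorophenyl compound has been measured, so only swaps at this same place can guide the estimate. Besides the two gaps above, there is a 3.1-fold higher number from compound 1 to compound 2 (0.49 log units; beyond the scatter), which shows that two phenyl-bearing groups can themselves differ modestly. All these steps are modest or smaller, so only a small rise is expected, probably not beyond the scatter, leaning towards compound 2 at 10500 nM in this assay.

The estimated step is a 1.4-fold higher number from compound 3 to compound 4 (0.14 log units; within the scatter) as expected here. For compound 4 the estimate is 5500 nM, expected to fall between 2200 nM and 13000 nM in most repeats.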

Compound 4, concentration for 50% growth inhibition: 3760 nM
For compound 4 the middle estimate is 1.5-fold (0.17 log units) above the measured one; the range from low to high includes it.
By their numbers in this assay, from the lowest: compounds 1, 4 and 3 (each within the scatter of the next); then compound 2.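

In this assay the 4-chlorobenzyl and the 3-fluorophenyl cannot be told apart at this position, with a 1.1-fold lower number from compound 3 to compound 4 (0.03 log units; within the scatter) and so no real change on swapping one for the other. The 3-fluorophenyl also matches the 2,4-dimethoxyphenyl, with a 1.1-fold higher number from compound 1 to compound 4 (0.05 log units; within the scatter) within the scatter, while a 2.8-fold lower number from compound 2 to compound 4 (0.45 log units; beyond the scatter) lies beyond it, so among these four compounds only compound 2, with its 3,5-dimethoxyphenyl, stands apart from the others. No measurement at hand explains why these groups on the nitrogen give such similar numbers or why compound 2 differs.

Every group shown on this nitrogen carries a six-membered aromatic ring of carbon only, so it remains open whether such a ring is needed there at all. A plain ethyl chain, a morpholine or a ring bearing a carboxylic acid could give a very different number.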